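The source may report more compounds than this note shows. Statements on the series, on what has been measured and on what is new or still open speak of the compounds shown alone.

Series notes. Compound 1 `Nc1sc(-c2ccccc2)c(-c2ccccc2)c1C(=O)c1ccc(Cl)cc1`, compound 2 `CC(C)(C)Cc1c(-c2ccoc2)sc(N)c1C(=O)c1ccc(Cl)cc1` and compound 3 `CC(C)(C)Cc1c(Br)sc(N)c1C(=O)c1cccc(C(F)(F)F)c1` share one core and were all tested in an assay on CHO cells for displacement of a labelled ligand from adenosine receptor A1 (Homo sapiens), read by scintillation counting, tested at 10 uM; on this read-out higher numbers stand for more inhibition at the one concentration tested (going by the name of the read-out) and lower numbers for less inhibition. Compound 1 gives 1% in this assay. Compound 2 gives 1% in this assay, and compound 3 gives 1% in this assay. Compound 2 thus stands level with compound 1 and compound 3 at the digits shown; the differences lie within the scatter, so no order among the three can be read, and none of them shows inhibition beyond the scatter at the concentration used.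

Compound 4 `CC(C)(C)Cc1c(-c2cccs2)sc(N)c1C(=O)c1ccc(Cl)cc1` has not yet been measured in this assay. It differs from compound 2 in one place: thiophen-2-yl in place of furan-3-yl on an aromatic carbon. For the measured compounds named here, no step between measured compounds shows what such a change does, and the three measured values give no sign that any variation on the core moves the read-out. The step in this assay is therefore expected to be none beyond the scatter, a number 1 percentage points higher from compound 2 to compound 4 (within the scatter). Compound 4 is expected to give 2% in this assay, within a range from 0% to 12%.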

Compound 4, a percentage reported as inhibition, at one concentration (the size of the read-out at that concentration, not a potency): 1%
The estimate for compound 4 lay 1 percentage points above the measured number, within the range that was stated.
By their numbers in this assay, from the lowest: compounds 1, 2, 3 and 4 (each within the scatter of the next).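

In this assay, for the compounds shown here, thiophen-2-yl in place of furan-3-yl on the aromatic carbon next to the ring sulfur gives no change at the digits printed from compound 2 to compound 4 (within the scatter) and is the only step that changes one place alone. At this position, then, exchanging one five-membered aromatic ring with 1 hetero atom for another, with sulfur entering and oxygen leaving, does not move the read-out beyond the scatter. No measurement available here bears on the reason for this result.

As far as these compounds go, whether this position can move the read-out at all stays open, since a swap between two such similar rings tests only a narrow change. An amine, a carboxylic acid or a longer chain on this carbon could show this, as could the same ring exchange on a compound with clear inhibition.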